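Pyridin-2-yl Replacing Methylphenyl on the Alkyne of Compound 3

A few compounds are considered here, and "the series" means these few. Any claim that something is new, unique, unknown or untested is made for them only; others in the source may bear on it.

Compound 3 `Cc1ccc(C#Cc2ccc3c(n2)CCN(C2CCCCC2)C3=O)cc1` is studied in an assay on HEK293 cells for displacement of a labelled ligand from metabotropic glutamate receptor 5 (Homo sapiens), with a stated time of 2 h (on this read-out higher numbers stand for weaker inhibition and lower numbers for stronger inhibition), where it gives 27200 nM. Among the two numbers obtained, this is the highest; the nearest is compound 1 `CC(C)N1CCc2nc(C#Cc3ccccn3)ccc2C1=O`, which in this assay gives 2740 nM, a gap of an at least 1.1-fold lower number from compound 2 to compound 3 (0.07 log units; that floor lies within the scatter) notwithstanding being a separate matter. Compound 2 `Cc1ccccc1C#Cc1ccc2c(n1)CCN(C1CCCCC1)C2=O` is reported in this assay only as a limit, > 32000 nM, and the limit of > 32000 nM in this assay, at which 1 of the 3 values shown sits, records this. The step from compound 2 to compound 3, 4-methylphenyl in place of 2-methylphenyl on a triple-bonded carbon, gave an at least 1.1-fold lower number from compound 2 to compound 3 (0.07 log units; that floor lies within the scatter).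

Compound 4 `O=C1c2ccc(C#Cc3ccccn3)nc2CCN1C1CCCCC1` differs from compound 3 by pyridin-2-yl in place of 4-methylphenyl on a triple-bonded carbon. Going by the values given here, no measured step exchanges an aryl group for pyridin-2-yl, so the step from compound 2 to compound 3 bears only loosely on it. Compound 1, however, carries the same pyridin-2-yl group on its triple-bonded carbon and gives 2740 nM, a far lower number than compound 3. On that basis compound 4 is expected to move in the direction of compound 1, a step of a 7.8-fold lower number from compound 3 to compound 4 (0.89 log units; beyond the scatter). The estimate for compound 4 in this assay is therefore 3500 nM, with a range from 900 nM to 14000 nM.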

Compound 4, inhibition constant: 2240 nM
Compound 4: middle estimate off by 1.6-fold (0.19 log units), on the high side, within the range that was stated.
By their numbers in this assay, from the lowest: compounds 4 and 1 (each within the scatter of the next); then compound 3. At a limit, above all of these: compound 2.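

In this assay, going by these compounds alone, pyridin-2-yl on a triple-bonded carbon gives the first step at this position that is clearly beyond the scatter, a 12-fold lower number from compound 3 to compound 4 (1.08 log units; beyond the scatter), whereas the only earlier step there, 4-methylphenyl in place of 2-methylphenyl, gave an at least 1.1-fold lower number from compound 2 to compound 3 (0.07 log units; that floor lies within the scatter). Read against the 2-methylphenyl group, the change gives an at least 14-fold lower number from compound 2 to compound 4 (1.15 log units; beyond the scatter), but this is only a floor, as compound 2 is held at a limit of the assay: the limit of > 32000 nM in this assay, at which 1 of the 4 values shown sits. With pyridin-2-yl on the triple-bonded carbon, the isopropyl and cyclohexyl groups on the amide-type nitrogen in a ring cannot be told apart, a 1.2-fold lower number from compound 1 to compound 4 (0.09 log units; within the scatter), so the cyclohexyl group alone does not go with the weak reading of compound 3.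

The compounds shown leave open whether the gain follows the ring nitrogen of pyridin-2-yl or the loss of the methyl group, which a plain phenyl or a pyridin-3-yl group on the triple-bonded carbon could separate. They also leave open how a benzyl group or a longer alkyl chain on the amide-type nitrogen would read with pyridin-2-yl kept in place.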